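One Methyl Group on an Aromatic Oxygen

A few compounds are considered here, and "the series" means these few. Any claim that something is new, unique, unknown or untested is made for them only; others in the source may bear on it.

Two related compounds have so far been measured in a functional assay on A549 cells (Homo sapiens) for cytotoxicity, read by XTT assay, with a stated time of 72 h (on this read-out higher numbers stand for weaker inhibition and lower numbers for stronger inhibition), for their effect on cancer cells. There, compound 1 `CC(C)=CCC/C=C(\C)Cc1c(O)cc(O)c2c(=O)cc(-c3ccccc3)oc12` gives an inhibitory concentration of 28000 nM and compound 2 `C=C1CC[C@H]2C(C)(C)CCC[C@]2(C)[C@H]1CC/C(C)=C/Cc1c(O)cc(O)c2c(=O)c(O)c(-c3ccc(O)cc3)oc12` gives 32000 nM. Compound 2 therefore stands within the usual scatter of compound 1, and the two numbers cannot be told apart.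

Compound 3 `C=C1CC[C@H]2C(C)(C)CCC[C@]2(C)[C@H]1CC/C(C)=C/Cc1c(O)cc(O)c2c(=O)c(O)c(-c3ccc(OC)cc3)oc12` is compound 2 with a single alteration. Its 4-hydroxyphenyl becomes 4-methoxyphenyl, with methyl in place of hydrogen on an oxygen on an aromatic ring. Within the data shown here, no measured pair shows this change on its own, so the data offer no direct precedent. The expectation rests only on compound 2 at 32000 nM and on the small size of the alteration. In this assay the expected step of a 1.1-fold lower number from compound 2 to compound 3 (0.03 log units; within the scatter) is no larger than the scatter, and no direction can be favoured. For compound 3 the estimated value is 30000 nM, with an expected range from 12000 nM to 70000 nM.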

Compound 3, half-maximal inhibitory concentration: > 100000 nM
Compound 3 was reported as a limit (the forecaster's own chance of this, stated with the estimate: 15%); middle value at least 3.3-fold (0.52 log units) away from the limit.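

In this assay, turning the 4-hydroxyphenyl into 4-methoxyphenyl gives an at least 3.1-fold higher number from compound 2 to compound 3 (0.49 log units; beyond the scatter), which means weaker inhibition of the cells. Among these compounds, this is the first direct reading of this position: adding a single methyl on an oxygen on an aromatic ring, a change of one carbon, moves the result beyond the scatter, so the position is not indifferent to small alterations. Compound 3 is reported only as a limit of the assay, so the step gives a minimum size and not an exact one: the limit of > 100000 nM in this assay, at which 1 of the 3 values shown sits.

The finding rests on one pair, so it cannot separate the loss of the hydrogen on that oxygen from the arrival of the methyl, and it gives no reason for the weaker inhibition. Also open, on these data alone, is how this position would respond to an ethyl or a longer chain on the same oxygen, or to an amine or a carboxylic acid in place of the hydroxy, and whether any such group would keep or improve on the result of compound 2.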